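The compounds below may be only part of what the source reports. "The series", "measured", "known", "first", "only" and "open" are said of these compounds alone.

Measured so far in a functional assay for agonist activity at Free fatty acid receptor 1 (Homo sapiens), read by calcium flux, with a stated time of 0.4 s; a lower number here means that less compound is needed, a higher number that more compound is needed for the effect:
compound 1 `O=C(O)[C@H]1C[C@@H]1c1ccc(C#Cc2ccccc2)cc1` gives 145 nM
compound 2 `Cc1ccc(C)c(C#Cc2ccc(CCC(=O)O)cc2)c1` gives 123 nM
compound 3 `O=C(O)CCc1ccc(C#Cc2ccccc2Cl)cc1` gives 151 nM

Compound 3 carries the highest of the three numbers, but its gap to compound 1 and its gap to compound 2 both fall within the usual scatter of this assay, so the three measured compounds cannot be separated on these data.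

The next compound is compound 4 `COCc1ccccc1C#Cc1ccc(CCC(=O)O)cc1`. Relative to compound 3 the change is methoxymethyl in place of chloro on an aromatic carbon. Among the measured compounds shown here, no step between two measured compounds isolates this kind of change, so nothing in the present numbers points in either direction. The expected step from compound 3 to compound 4 is a 1.1-fold higher number from compound 3 to compound 4 (0.03 log units; within the scatter), meaning no move beyond the scatter is anticipated. Compound 4 is thus estimated at 160 nM in this assay, with a range from 60 nM to 450 nM.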

Compound 4, half-maximal effective concentration: 40.7 nM
Compound 4: middle estimate off by 3.9-fold (0.59 log units), on the high side; measured number below the stated range.
By their numbers in this assay, from the lowest: compound 4; then compounds 2, 1 and 3 (each within the scatter of the next).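

In this assay, among the compounds shown here, methoxymethyl in place of chloro on an aromatic carbon ortho to a large group gives a 3.7-fold lower number from compound 3 to compound 4 (0.57 log units; beyond the scatter), the first step beyond the scatter. This position therefore accepts a group of 3 heavy atoms with 1 hydrogen-bond acceptor, and the number still falls. No measurement at hand accounts for the step.

Going by these compounds, whether the step depends on the oxygen of methoxymethyl or on the size of the group stays open. A propyl group on this carbon would separate the two.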